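A few compounds are considered here, and "the series" means these few. Any claim that something is new, unique, unknown or untested is made for them only; others in the source may bear on it.

Measured compounds and their values in a functional assay on A498 cells (Homo sapiens) for inhibition, read by sulforhodamine B assay, with a stated time of 48 h, tested at 0.1 uM; on this read-out lower numbers stand for a stronger effect and higher numbers for a weaker effect at the one concentration tested:

- compound 1 `COc1cc(Cl)cc(-c2nn(-c3cccc(NC(=O)Nc4ccc(Cl)c(C(F)(F)F)c4)c3)cc2-c2ccncc2)c1` gives 59%
- compound 2 `COc1cc(Cl)cc(-c2nn(-c3cccc(NC(=O)Nc4cc(C(F)(F)F)cc(C(F)(F)F)c4)c3)cc2-c2ccncc2)c1` gives 69%
- compound 3 `COc1cc(Cl)cc(-c2nn(-c3cccc(NC(=O)Nc4ccc(Cl)c(Cl)c4)c3)cc2-c2ccncc2)c1` gives 58%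

Compound 3 stands lowest of the three numbers, but only compound 2 is clearly apart from it; compound 1 lies within the usual scatter of compound 3. Among the measured compounds shown here, the one single-point step that has been measured, a number 1 percentage points lower from compound 1 to compound 3 (within the scatter), shows that swapping one halogen-type group for another on the outer aromatic ring left the read-out essentially unchanged.

Compound 4 `COc1cc(Cl)cc(-c2nn(-c3cccc(NC(=O)Nc4cccc(C(F)(F)F)c4)c3)cc2-c2ccncc2)c1` is the next step. Compared with compound 3 the change is 3-(trifluoromethyl)phenyl in place of 3,4-dichlorophenyl on an amide-type nitrogen. This is not a simple swap of one group for another: one substituent of the outer ring disappears and the remaining one becomes a trifluoromethyl. For the measured compounds named here, no measured step covers the loss of a substituent. Compound 1 and compound 3 show that like-for-like exchanges on this ring barely move the read-out, while compound 2, carrying two trifluoromethyl groups, gives a weaker effect. A modest step toward weaker activity, a number 6 percentage points higher from compound 3 to compound 4 (within the scatter), is therefore expected for compound 4, though it may well fall within the scatter. The estimate for compound 4 in this assay is 64%, with a likely range from 53% to 75%.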

Compound 4, a percentage reported as activity, at one concentration (the size of the read-out at that concentration, not a potency): 92%
Estimate against measurement, compound 4: 28 percentage points below, outside the stated range (above it).
By their numbers in this assay, from the lowest: compounds 3, 1 and 2 (each within the scatter of the next, the first and the last beyond it); then compound 4.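

In this assay, removing a group from the outer ring weakens the effect, as seen with chloro in a number 33 percentage points higher from compound 1 to compound 4 (beyond the scatter) and with trifluoromethyl in a number 23 percentage points higher from compound 2 to compound 4 (beyond the scatter). The earlier exchanges had only replaced one group with another, so they could not show that the outer ring with trifluoromethyl alone does so much worse than the rings carrying two groups. The full change from 3,4-dichlorophenyl to 3-(trifluoromethyl)phenyl fits this picture, giving a number 34 percentage points higher from compound 3 to compound 4 (beyond the scatter), and no evidence here explains any of these shifts.

Still open, from the compounds shown here alone, is whether a methyl, a methoxy or an amine as the second group would bring the effect back as chloro does. It is also unknown how a plain phenyl with no groups at all would compare with compound 4.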